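A few compounds are considered here, and "the series" means these few. Any claim that something is new, unique, unknown or untested is made for them only; others in the source may bear on it.

Of the compounds shown here, three have so far been measured in a physicochemical assay for lipophilicity, read by NMR; on this read-out higher numbers stand for higher lipophilicity and lower numbers for lower lipophilicity. Compound 1, `CC(=O)N1CCC[C@H]1C(=O)OCCF`, gives -0.43, the lowest of the three numbers. Compound 3, `OCCC(F)(F)CF`, gives 0.27, and compound 2, `CC(F)(F)C(F)(F)CO`, gives 0.87; both of these stand beyond the scatter higher than compound 1. Compound 4, `CC(=O)N1CCC[C@H]1C(=O)OCC(F)F`, differs from compound 1 in one place: fluoro in place of hydrogen on a saturated chain carbon bound to a fluorine atom and a saturated chain carbon. Going by the values given here, no pair of measured compounds isolates exactly this change, so the expectation rests on the measured numbers and the nature of the change alone. A small upward step is expected, close to the edge of the scatter. The step expected is a number 0.23 log units higher from compound 1 to compound 4 (within the scatter). In this assay compound 4 is therefore estimated at -0.2, with a range from -0.5 to 0.1.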

Compound 4, partition coefficient: 0.02
The estimate for compound 4 lay 0.22 log units below the measured number; the range from low to high includes it.
By their numbers in this assay, from the lowest: compound 1; then compounds 4 and 3 (each within the scatter of the next); then compound 2.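

In this assay, replacing 2-fluoroethoxy with 2,2-difluoroethoxy on the shared core gives a number 0.45 log units higher from compound 1 to compound 4 (beyond the scatter). This is the only single-place step shown here, so it gives the first direct reading of a second fluoro on this saturated chain carbon, though from one pair alone. Nothing available explains why the number moves. Going by these compounds, whether a third fluorine, giving 2,2,2-trifluoroethoxy, would move the number further remains open. So does whether the same change on a longer chain, or on a core carrying an amine, would give a step of similar size.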